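Cyclopropyl for methylsulfanyl: clearance notes

This account rests on a few compounds, and the source may have more. Where it says the series, first, only, none or still open, it means among the compounds named here.

Measured in an ADME assay on microsomes from liver (Homo sapiens) for metabolic stability; a lower number here means slower removal, a higher number faster removal of the compound:
compound 1 `CCOC(=O)N1C[C@@H]2C[C@H]1CN2c1nc(SC)cc(-c2cnc(N)c(OC(F)F)n2)n1`: 12.3 mL/min/kg
compound 2 `Nc1ncc(-c2cc([C@@H]3CCCO3)nc(N3C[C@@H]4C[C@H]3CO4)n2)nc1OC(F)F`: 12.6 mL/min/kg
compound 3 `CSc1cc(-c2cnc(N)c(OC(F)F)n2)nc(N2C[C@@H]3C[C@H]2CO3)n1`: 5.7 mL/min/kg
Not yet measured: compound 4 `CCOC(=O)N1C[C@@H]2C[C@H]1CN2c1nc(-c2cnc(N)c(OC(F)F)n2)cc(C2CC2)n1`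

Compound 1 stands level with compound 2 within the scatter and higher than compound 3. Compound 4 carries cyclopropyl in place of methylsulfanyl on an aromatic carbon. Going by the values given here, one measured step bears on this: a 2.2-fold lower number from compound 2 to compound 3 (0.34 log units; beyond the scatter). It brings methylsulfanyl in and takes a ring out, the reverse sense of the present change, though with a different ring and a different partner group on the core. A small rise in this assay is therefore expected, smaller than that step and perhaps not beyond the scatter. The estimate amounts to a 1.2-fold higher number from compound 1 to compound 4 (0.09 log units; within the scatter). For compound 4 the expected value is 15 mL/min/kg, with an estimated range of 8 mL/min/kg to 27 mL/min/kg.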

Compound 4, clearance: 12.6 mL/min/kg
Compound 4: the middle estimate sits 1.2-fold (0.08 log units) above what was measured; low and high end bracket the measured number.
By their numbers in this assay, from the lowest: compound 3; then compounds 1, 2 and 4 (each within the scatter of the next).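

In this assay cyclopropyl in place of methylsulfanyl gives a 1.0-fold higher number from compound 1 to compound 4 (0.01 log units; within the scatter) and the two compounds stand level on this core. The earlier step, a 2.2-fold lower number from compound 2 to compound 3 (0.34 log units; beyond the scatter), involved oxolan-2-yl and a different partner group, so a ring on this aromatic carbon does not always go with a higher number than methylsulfanyl; compound 2 against compound 3 is the case where it does. No available evidence explains why the two steps read differently.

Open, going by these compounds, is how an amine or a longer carbon chain on this aromatic carbon would read in this assay. Also open, on these data alone, is how oxolan-2-yl would read with the partner group of compound 1.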